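Swapping an oxazole for a butyl imidazole on the piperazine

The source may hold more compounds than are shown below. What is called first, only, known or untested is meant among the compounds shown, and "the series" means these compounds.

Compound 1 `CCc1nc(C)c(CN2CCN(c3cccc4[nH]c(-c5ccc(C(C)(C)C)cc5)nc34)CC2)o1`: 320 nM
Compound 2 `Cc1nc(CN2CCN(c3cccc4[nH]c(-c5ccc(C(C)(C)C)cc5)nc34)CC2)cn1C`: 34 nM

Going by the values given here, in an assay on isolated protein for displacement of a labelled ligand from Gonadotropin-releasing hormone receptor (Rattus norvegicus) (a higher number here means a weaker inhibitor, a lower number a stronger inhibitor), compound 1 gives 320 nM, the higher of the two numbers measured so far, and compound 2 gives 34 nM. Among the compounds with values here, the one measured step, a 9.4-fold lower number from compound 1 to compound 2 (0.97 log units; beyond the scatter), changes only the five-membered ring hanging from the chain carbon bound to the ring amine nitrogen.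

Compound 3 `CCCCc1nc(CN2CCN(c3cccc4[nH]c(-c5ccc(C(C)(C)C)cc5)nc34)CC2)cn1C` has not been measured. It differs from compound 1 by 2-butyl-1-methyl-1H-imidazol-4-yl in place of 2-ethyl-4-methyl-1,3-oxazol-5-yl on a saturated chain carbon bound to an amine nitrogen in a ring; that is, it carries the same imidazole as compound 2, but with a butyl chain where compound 2 carries a methyl. The step from compound 1 to compound 2 is the only one that bears on this change, and it covers the ring swap but not the longer chain. Nothing measured tells how the butyl chain behaves, so the expectation rests on the ring swap alone.

Compound 3 is therefore expected to land near compound 2, with a step of about a 7.1-fold lower number from compound 1 to compound 3 (0.85 log units; beyond the scatter) in this assay, and an estimated value of 45 nM, within a range of 12 nM to 170 nM.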

Compound 3, half-maximal inhibitory concentration: 58 nM
Compound 3: middle estimate off by 1.3-fold (0.11 log units), on the low side; the measured number falls inside the stated range.
By their numbers in this assay, from the lowest: compounds 2 and 3 (each within the scatter of the next); then compound 1.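

Replacing the methyl on the imidazole with a butyl chain gives a 1.7-fold higher number from compound 2 to compound 3 (0.23 log units; within the scatter) in this assay, so this read-out cannot tell the two chains apart and the position accepts the longer one without a clear loss. The advantage over the oxazole also holds with the butyl chain in place: a 5.5-fold lower number from compound 1 to compound 3 (0.74 log units; beyond the scatter) lies beyond the scatter, so both imidazoles shown give lower numbers than the single oxazole. Nothing available here explains why the ring swap matters or why the chain length makes no clear difference.

Only a methyl and a butyl chain are shown on the imidazole, so it remains open whether an octyl chain, a phenyl ring or a chain ending in a carboxylic acid would keep the number in this range. The oxazole and the imidazoles also differ in the groups they carry as well as in the ring itself, so an oxazole bearing a butyl chain would be needed to separate the effect of the ring from that of its side groups.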